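Nitrile enone indole series: aryl swap at chlorovinyl carbon

A few compounds are considered here, and "the series" means these few. Any claim that something is new, unique, unknown or untested is made for them only; others in the source may bear on it.

Two compounds of this series have numbers in a functional assay for inhibition, read by Griess assay, with a stated time of 150 min, tested at 1 mM; a higher number here means more inhibition at the concentration tested (going by the name of the read-out), a lower number less inhibition. Compound 1 `COc1cc(/C(Cl)=C/C=C(\C#N)C(=O)c2c[nH]c3ccccc23)cc(OC)c1OC` gives 73.3%. Compound 2 `COc1ccc2[nH]cc(C(=O)/C(C#N)=C/C=C(\Cl)c3ccc(OC)c(OC)c3)c2c1` gives 74.2%, the higher of the two numbers, though its gap to compound 1 lies within the scatter, so no order between them is claimed. Compound 3 `COc1ccc2[nH]cc(C(=O)/C(C#N)=C/C=C(\Cl)c3ccc(Br)cc3)c2c1` is not yet measured. It differs from compound 2 by 4-bromophenyl in place of 3,4-dimethoxyphenyl on a double-bonded chain carbon bound to a chlorine atom and a double-bonded chain carbon. Among the measured compounds shown here, no step between measured compounds is known for this kind of change; a small loss, or none beyond the scatter, is expected in this assay . Compound 3 is estimated at 65%, between 45% and 82%, an expected step of a number 9.2 percentage points lower from compound 2 to compound 3 (within the scatter).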

Compound 3, a percentage reported as inhibition, at one concentration (the size of the read-out at that concentration, not a potency): 76.7%
Compound 3: middle estimate off by 11.7 percentage points, on the low side, within the range that was stated.
By their numbers in this assay, from the lowest: compounds 1, 2 and 3 (each within the scatter of the next).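

In this assay, 4-bromophenyl in place of 3,4-dimethoxyphenyl on a double-bonded chain carbon bound to a chlorine atom and a double-bonded chain carbon gives a number 2.5 percentage points higher from compound 2 to compound 3 (within the scatter). This position therefore accepts an aryl group with no hydrogen-bond acceptors and no methoxy groups without a change beyond the scatter. Nothing available explains this result.

Open, from the compounds shown here alone, is whether the number holds with a dimethylamino group or a longer chain in place of the aryl ring. Readings at one concentration also leave any difference in potency between these compounds open.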